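Aryl exchange on the aromatic nitrogen, compound 3 expected

A few compounds are considered here, and "the series" means these few. Any claim that something is new, unique, unknown or untested is made for them only; others in the source may bear on it.

Compound 1 `N#CC1=C(N)Oc2c(N)cc3nc4ccccc4nc3c2C12C(=O)N(Cc1cnnn1-c1ccccc1Br)c1ccccc12` — 12400 nM in a functional assay on HCT-116 cells (Homo sapiens) for antiproliferative activity, read by MTT assay, with a stated time of 48 h; a higher number here means a weaker inhibitor, a lower number a stronger inhibitor
Compound 2 `N#CC1=C(N)Oc2c(N)cc3nc4ccccc4nc3c2C12C(=O)N(Cc1cnnn1-c1ccc([N+](=O)[O-])cc1)c1ccccc12` — > 50000 nM in this assay, a limit of the assay rather than a number

Going by the values given here, compound 2 stands at the limit (the limit of > 50000 nM in this assay, at which 1 of the 2 values shown sits), so in this assay only one of the two values is a measured number. Among the compounds with values here, the one measured step is an at least 4.0-fold higher number from compound 1 to compound 2 (0.60 log units; beyond the scatter), where 4-nitrophenyl replaced 2-bromophenyl on the aromatic nitrogen and gave a weaker inhibitor.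

Compound 3 `N#CC1=C(N)Oc2c(N)cc3nc4ccccc4nc3c2C12C(=O)N(Cc1cnnn1-c1c(F)cccc1F)c1ccccc12` differs from compound 2 as 2,6-difluorophenyl in place of 4-nitrophenyl on an aromatic nitrogen. The change reverses the direction of that step by removing the 4-nitrophenyl, and the entering 2,6-difluorophenyl is nearer in kind to the 2-bromophenyl of compound 1 than to the group it replaces. A modest return toward the number for compound 1 is therefore expected, without confidence about the full size since compound 2 sits at a limit.

Compound 3 is estimated at 15000 nM, range 5000 nM to 50000 nM, an expected step of an at least 3.3-fold lower number from compound 2 to compound 3 (0.52 log units; beyond the scatter).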

Compound 3, half-maximal inhibitory concentration: > 50000 nM
Compound 3 gave a limit, no number; the forecaster's own chance of this, stated with the estimate: 25%; middle value at least 3.3-fold (0.52 log units) away from the limit.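

In this assay compound 3 gives > 50000 nM, which is a limit of the assay and not a number. Exchanging the 2-bromophenyl on the aromatic nitrogen for 2,6-difluorophenyl gives an at least 4.0-fold higher number from compound 1 to compound 3 (0.60 log units; beyond the scatter), so the loss of activity at this position is not confined to the 4-nitrophenyl, and compound 1 is the only one of the three aryl variants with a measured number. The step between compound 2 and compound 3 cannot be read, and the aryl variants now gather at a single limit: the limit of > 50000 nM in this assay, at which 2 of the 3 values shown sit.

From the compounds shown here alone, it remains open whether the bromine of compound 1 contributes to its measured value, which an unsubstituted phenyl on the same nitrogen would help to test. Also open, going by these compounds, is whether a benzyl group, an amine-bearing phenyl or a short alkyl chain at this position would give a measured number.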